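This account rests on a few compounds, and the source may have more. Where it says the series, first, only, none or still open, it means among the compounds named here.

Of the compounds shown here, three sharing one core have been measured in a functional assay on PC-3 cells (Homo sapiens) for inhibition; a higher number here means a weaker inhibitor, a lower number a stronger inhibitor. Compound 1, `COc1cc2nc(N3CCN(S(=O)(=O)c4ccc(C(F)(F)F)cc4)CC3)nc(N)c2cc1OC`, gives 27000 nM. Compound 2, `COc1cc2nc(N3CCN(S(=O)(=O)c4ccc(S(C)(=O)=O)cc4)CC3)nc(N)c2cc1OC`, gives 17000 nM. Compound 3, `COc1cc2nc(N3CCN(S(=O)(=O)c4ccc(-c5ccc(C(F)(F)F)cc5)cc4)CC3)nc(N)c2cc1OC`, gives 3300 nM. The step from compound 1 to compound 2 reads a 1.6-fold lower number from compound 1 to compound 2 (0.20 log units; within the scatter), and the change behind it is methylsulfonyl in place of trifluoromethyl on an aromatic carbon. The step to compound 3 is larger: an 8.2-fold lower number from compound 1 to compound 3 (0.91 log units; beyond the scatter), where the change is 4-(trifluoromethyl)phenyl in place of trifluoromethyl on an aromatic carbon; likewise a 5.2-fold lower number from compound 2 to compound 3 (0.71 log units; beyond the scatter). Among these three, compound 3 carries the lowest number, and its distance to both others lies beyond the scatter.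

Compound 4, `COc1cc2nc(N3CCN(S(=O)(=O)c4ccc(-c5ccc(S(C)(=O)=O)cc5)cc4)CC3)nc(N)c2cc1OC`, has not yet been measured in this assay. Its difference from compound 3 is methylsulfonyl in place of trifluoromethyl on an aromatic carbon. This is the same change that was made from compound 1 to compound 2: the groups that leave and enter are the same, and the place lines of the two changes agree word for word. The cores on which the change is made differ, and that difference is what is counted under (4-(trifluoromethyl)phenyl in place of trifluoromethyl on an aromatic carbon). Since the earlier step of this change, a 1.6-fold lower number from compound 1 to compound 2 (0.20 log units; within the scatter), stayed within the scatter, the step from compound 3 to compound 4 is expected to be of a similar modest size, a 1.5-fold lower number from compound 3 to compound 4 (0.18 log units; within the scatter), resting only on that single precedent. Compound 4 is therefore estimated at 2200 nM, with a range from 900 nM to 5500 nM.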

Compound 4, half-maximal inhibitory concentration: 7200 nM
Compound 4: the middle estimate sits 3.3-fold (0.51 log units) below what was measured; measured number outside the range, above it.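

In this assay methylsulfonyl in place of trifluoromethyl gives a 2.2-fold higher number from compound 3 to compound 4 (0.34 log units; beyond the scatter) on the larger core, so the change did not carry over with its earlier outcome from the core of compound 1. The added aromatic ring still goes with a lower number in the methylsulfonyl series, as seen in a 2.4-fold lower number from compound 2 to compound 4 (0.37 log units; beyond the scatter) and also in a 3.8-fold lower number from compound 1 to compound 4 (0.57 log units; beyond the scatter) where the group that leaves is trifluoromethyl. The result shows that, for these two pairs, the outcome of this change depends on the core, but with only two steps it does not show why they differ or how the change would run on any further core: the same change on two cores in this assay, a 1.6-fold lower number (0.20 log units; within the scatter) from compound 1 to compound 2 and a 2.2-fold higher number (0.34 log units; beyond the scatter) from compound 3 to compound 4, 3.5-fold (0.54 log units) apart, beyond the scatter of two such steps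

The compounds shown leave open how an amine, a carboxylic acid or a nitrile would read in place of trifluoromethyl and methylsulfonyl on an aromatic carbon of either core. They also leave open whether a longer chain in that place would follow the steps seen with compound 3 and compound 4 or those seen with compound 1 and compound 2.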